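A few compounds are considered here, and "the series" means these few. Any claim that something is new, unique, unknown or untested is made for them only; others in the source may bear on it.

Measured compounds in an assay on CHO-K1 cells for displacement of a labelled ligand from 5-hydroxytryptamine receptor 7 (Homo sapiens), read by scintillation counting; on this read-out higher numbers stand for weaker inhibition and lower numbers for stronger inhibition:
- compound 1 `COc1ccccc1N1CCN(CCCCC(=O)NCc2ccccc2-c2ccc(Cl)cc2)CC1` gives 25.9 nM
- compound 2 `COc1ccccc1N1CCN(CCCCC(=O)NCc2ccccc2-c2cccc(F)c2)CC1` gives 34.7 nM
- compound 3 `COc1ccccc1N1CCN(CCCCC(=O)NCc2ccccc2-c2ccccc2C)CC1` gives 26.1 nM

On these numbers compound 3 stands second highest of three, yet all three values lie within the scatter of one another: a 1.0-fold higher number from compound 1 to compound 3 (0.00 log units; within the scatter), a 1.3-fold lower number from compound 2 to compound 3 (0.12 log units; within the scatter) and a 1.3-fold higher number from compound 1 to compound 2 (0.13 log units; within the scatter). Compound 4 `COc1ccccc1N1CCN(CCCCC(=O)NCc2ccccc2-c2cccc(Cl)c2)CC1` differs from compound 3 by 3-chlorophenyl in place of 2-methylphenyl on an aromatic carbon. The three measured steps all swap one substituted phenyl for another on this same aromatic carbon, and none of them moved the inhibition constant beyond the scatter, so no step beyond the scatter is expected here either: the expected step is a 1.1-fold higher number from compound 3 to compound 4 (0.03 log units; within the scatter). Compound 4 is therefore estimated at 28 nM, with a range from 14 nM to 56 nM.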

Compound 4, inhibition constant: 405 nM
Compound 4: the middle estimate sits 14-fold (1.16 log units) below what was measured, outside the stated range (above it).
By their numbers in this assay, from the lowest: compounds 1, 3 and 2 (each within the scatter of the next); then compound 4.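

Moving the chlorine alone matters at this aromatic carbon, which the earlier swaps gave no sign of: 3-chlorophenyl in place of 4-chlorophenyl gives (a 16-fold higher number from compound 1 to compound 4 (1.19 log units; beyond the scatter)). Chloro in place of fluoro on the same ring gives (a 12-fold higher number from compound 2 to compound 4 (1.07 log units; beyond the scatter)), and 3-chlorophenyl in place of 2-methylphenyl gives (a 16-fold higher number from compound 3 to compound 4 (1.19 log units; beyond the scatter)), so compound 4 alone breaks the flat run of compounds 1, 2 and 3. No measurement at hand accounts for this loss. On these data alone, whether a 3-methylphenyl, a 3-methoxyphenyl or a phenyl bearing an amine would side with compound 4 or with the other three stays open.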